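This account rests on a few compounds, and the source may have more. Where it says the series, first, only, none or still open, it means among the compounds named here.

In a functional assay on K562 cells (Homo sapiens) for cytotoxicity, read by MTT assay, with a stated time of 5 days (on this read-out higher numbers stand for weaker inhibition and lower numbers for stronger inhibition), two compounds have been measured so far. Compound 1 (`COc1ccc(-c2cnnn2-c2cc(OC)c(OC)c(OC)c2)cc1N`) gives 11 nM. Compound 2 (`COc1ccc(Cn2nncc2-c2cc(OC)c(OC)c(OC)c2)cc1`) gives 8660 nM, the higher of the two numbers and so the weaker inhibition, and the gap between them lies beyond the usual scatter of repeated measurements.

Compound 3 (`COc1ccc(Cn2nncc2-c2cc(OC)c(OC)c(OC)c2)cc1Br`) is compound 2 with a single change, from 4-methoxyphenyl to 3-bromo-4-methoxyphenyl: bromo in place of hydrogen on an aromatic carbon. Among the measured compounds shown here, no measured pair shows this change on its own, so the data offer no direct guide to its size. A moderate move towards a lower number in this assay is expected, though the outcome could still fall within the scatter. The expected change is estimated as a 2.5-fold lower number from compound 2 to compound 3 (0.39 log units; beyond the scatter). Compound 3 is estimated to give about 3500 nM, within a range of 800 nM to 15000 nM.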

Compound 3, half-maximal inhibitory concentration: > 10000 nM
Compound 3 gave a limit, no number; the forecaster's own chance of this, stated with the estimate: 15%; middle value at least 2.8-fold (0.45 log units) away from the limit.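

In this assay, placing bromo on this aromatic carbon, ortho to a methoxy group, brings no sign of stronger inhibition, and the step reads as an at least 1.1-fold higher number from compound 2 to compound 3 (0.06 log units; that floor lies within the scatter). The result for compound 3 is a limit of the assay and not a number, so the step gives only a floor and its true size stays unknown: the limit of > 10000 nM in this assay, at which 1 of the 3 values shown sits.

Among the compounds shown here, this is still new information, since the earlier compounds gave no direct read on any change at this carbon, and here the expected move towards a lower number does not appear.

As far as these compounds go, whether fluoro, a hydroxy group or an amine on the same carbon would lower the number remains open. Also open is whether bromo would act the same way on another compound, as the single step shown compares only hydrogen and bromo on the 4-methoxyphenyl ring.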